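This account rests on a few compounds, and the source may have more. Where it says the series, first, only, none or still open, it means among the compounds named here.

Measured compounds:
- compound 1 `CCn1c(C(=O)Nc2ccc(OC(F)(F)F)cc2)ccc1C(CC)(CC)c1ccc(OCCC(O)(CC)CC)c(C)c1` — > 50000 nM
- compound 2 `CCn1c(C(=O)Nc2cccc(C(F)(F)F)c2)ccc1C(CC)(CC)c1ccc(OCCC(O)(CC)CC)c(C)c1` — 23800 nM
- compound 3 `CCC(C)C(CO)NC(=O)c1ccc(C(CC)(CC)c2ccc(OCCC(O)(CC)CC)c(C)c2)n1CC` — 28400 nM

All three share the same core and differ only in the group on the amide-type nitrogen. In a functional assay on PC-3 cells (Homo sapiens) for antiproliferative activity, read by MTT assay, with a stated time of 48 h (on this read-out lower numbers stand for stronger inhibition and higher numbers for weaker inhibition), compound 1 gives only a limit, > 50000 nM, a limit of the assay and not a number (the limit of > 50000 nM in this assay, at which 1 of the 3 values shown sits). Compound 2 gives 23800 nM, and compound 3 gives 28400 nM; the two sit within the scatter of each other, as the step of a 1.2-fold higher number from compound 2 to compound 3 (0.08 log units; within the scatter) shows, so neither can be set apart. Between them, compound 2 is the reference here.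

Compound 4 `CCn1c(C(=O)N(C)CCO)ccc1C(CC)(CC)c1ccc(OCCC(O)(CC)CC)c(C)c1` has not been measured in this assay. Its change from compound 2: (2-hydroxyethyl)(methyl)amino in place of (3-(trifluoromethyl)phenyl)amino on a carbonyl carbon. Both measured steps from compound 1, an at least 2.1-fold lower number from compound 1 to compound 2 (0.32 log units; beyond the scatter) and an at least 1.7-fold lower number from compound 1 to compound 3 (0.24 log units; that floor lies within the scatter), start from a limit and end within the same narrow band; the one aliphatic replacement, compound 3, moved nothing beyond the scatter against compound 2. The step to compound 4 is likewise an aliphatic replacement with one hydrogen-bond donor retained, so no step beyond the scatter is expected in this assay, with the direction left open.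

For compound 4 the expected value is 30000 nM, within 12000 nM to 80000 nM, an expected step of a 1.3-fold higher number from compound 2 to compound 4 (0.10 log units; within the scatter).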

Compound 4, half-maximal inhibitory concentration: 3090 nM
Compound 4: middle estimate off by 9.7-fold (0.99 log units), on the high side, and the stated range ends above it.
By their numbers in this assay, from the lowest: compound 4; then compounds 2 and 3 (each within the scatter of the next). At a limit, above all of these: compound 1.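

In this assay, the group on the carbonyl carbon can move the number well beyond the scatter, which compound 2 and compound 3 did not show against each other. Two steps do show it: a 7.7-fold lower number from compound 2 to compound 4 (0.89 log units; beyond the scatter), and a 9.2-fold lower number from compound 3 to compound 4 (0.96 log units; beyond the scatter). Losing the aromatic ring is not enough to account for this, since compound 3 also carries an aliphatic group with a hydroxyl and goes against any such reading, while the hydrogen-bond donor count stays the same in the group that leaves compound 2 and the one that enters, and the widest gap in the set is an at least 16-fold lower number from compound 1 to compound 4 (1.20 log units; beyond the scatter). That gap is only a floor, as compound 1 gives a limit of the assay and not a number: the limit of > 50000 nM in this assay, at which 1 of the 4 values shown sits.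

The compounds shown do not separate the contribution of the methyl on the amide-type nitrogen from that of the 2-hydroxyethyl chain, so it remains unclear which part of the change carries the step. A plain dimethylamino group, a 2-hydroxyethylamino group without the methyl, or a longer 3-hydroxypropyl chain would bear on that question.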